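The compounds below may be only part of what the source reports. "The series", "measured", "known", "first", "only" and "open" are said of these compounds alone.

Measured compounds:
- compound 1, `CCCCC#Cc1c[nH]c(=O)[nH]c1=O`; in an ADME assay on A549 cells (Homo sapiens) for cytotoxicity, read by MTT assay (on this read-out higher numbers stand for lower toxicity in this test and lower numbers for higher toxicity in this test), compound 1 gives 250000 nM
- compound 2, `O=c1[nH]cc(C#CC(O)c2ccccc2)c(=O)[nH]1`; compound 2 gives 237000 nM
- compound 3, `O=c1[nH]c(=O)n([C@@H]2O[C@H](CO)[C@@H](O)[C@H]2O)cc1C#Cc1ccccc1`; compound 3 gives 42500 nM

Of the three, compound 3 stands lowest in this assay, which here means it is the most toxic of the set: its number lies beyond the scatter below both compound 2 and compound 1, those two sitting close to each other. Within the data shown here, compounds 1 and 2 carry no sugar on the shared core; compound 3 does, and it is the only such compound measured, so nothing can be drawn from that pairing beyond the two values themselves.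

The unmeasured compound 4, `O=c1[nH]c(=O)n([C@@H]2O[C@H](CO)[C@@H](O)[C@H]2O)cc1C#CC1CCCCC1`, keeps the sugar and the triple bond of compound 3 and changes only the group at the far end: cyclohexyl in place of phenyl on a triple-bonded carbon. Among the measured compounds shown here, no pair of measured compounds isolates a change of this kind, so there is no measured step to lean on. The expectation is therefore a small step in this assay from compound 3 to compound 4, a 1.3-fold higher number from compound 3 to compound 4 (0.11 log units; within the scatter), not clearly beyond the scatter and, if anything, toward a slightly higher number. Compound 4 is expected to give about 55000 nM, most likely between 20000 nM and 150000 nM.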

Compound 4, half-maximal cytotoxic concentration: 127000 nM
Beside the measured number, compound 4's estimate is 2.3-fold (0.36 log units) below it, within the range that was stated.
By their numbers in this assay, from the lowest: compound 3; then compounds 4, 2 and 1 (each within the scatter of the next).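

On a triple-bonded carbon whose other neighbours are: triple-bonded carbon, cyclohexyl in place of phenyl gives a 3.0-fold higher number from compound 3 to compound 4 (0.48 log units; beyond the scatter) in this assay, a modest step toward lower toxicity in this test and the first single-place change measured in this series. Phenyl and cyclohexyl carry the same count of carbon, no hydrogen-bond donors or acceptors and no net charge, and each is a six-membered ring of carbon only, so in this pair the number moves beyond the scatter with a swap whose counted difference is that the ring is no longer aromatic. Nothing available here accounts for the size or direction of this step.

From the compounds shown here alone, this reading rests on one pair carrying the sugar, so it remains open whether cyclohexyl in place of phenyl would give a like step on the shared core without the sugar. Going by these compounds, it also remains open how an amine, a carboxylic acid or a longer chain in this same place would compare with phenyl and cyclohexyl.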